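The source may hold more compounds than are shown below. What is called first, only, known or untested is meant among the compounds shown, and "the series" means these compounds.

In a physicochemical assay for solubility, in phosphate buffer, with a stated time of 24 h, at pH 7.4 (a higher number here means a more soluble compound, a lower number a less soluble compound), compound 1 `COc1cncc(-c2cccc(-c3cn4ccc(OC)c(C(N)=O)c4n3)c2)c1` gives 40000 nM. Its analogue compound 3 `COc1ccn2cc(-c3cccc(-c4cncc(OC[C@H]5CCCO5)c4)c3)nc2c1C(N)=O` carries the change oxolan-2-yl in place of hydrogen on a saturated chain carbon bound to an oxygen on an aromatic ring and gives 120000 nM, so the step of a 3.0-fold higher number from compound 1 to compound 3 (0.48 log units; beyond the scatter) is a modest rise. Compound 2 `COc1cncc(-c2cccc(-c3cn4ccnc(C(N)=O)c4n3)c2)c1` shares the same two-ring arrangement but on a different core, and the difference between the two cores is not broken down here; in this assay compound 2 gives 10000 nM, the lowest of the three numbers. Compound 4 `NC(=O)c1nccn2cc(-c3cccc(-c4cncc(OC[C@H]5CCCO5)c4)c3)nc12` is compound 2 with the same change, (oxolan-2-yl in place of hydrogen on a saturated chain carbon bound to an oxygen on an aromatic ring), that took compound 1 to compound 3. On that single precedent, the step is expected to be of similar size, a 3.0-fold higher number from compound 2 to compound 4 (0.48 log units; beyond the scatter), matching a 3.0-fold higher number from compound 1 to compound 3 (0.48 log units; beyond the scatter). Compound 4 is therefore estimated at 30000 nM, within 12000 nM to 75000 nM.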

Compound 4, solubility: 40000 nM
Compound 4: middle estimate off by 1.3-fold (0.12 log units), on the low side; measured number inside the range.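

In this assay the change from methoxy to (oxolan-2-yl)methoxy gives a 4.0-fold higher number from compound 2 to compound 4 (0.60 log units; beyond the scatter) on one core, in the same direction as a 3.0-fold higher number from compound 1 to compound 3 (0.48 log units; beyond the scatter) on the other, and both modest rises lie beyond the usual scatter. The rise therefore carried over between these two cores, but with one pair per core this does not show that it would hold on any further core. Nothing shown here accounts for the rise on either core.

The compounds shown leave open whether an amine, a carboxylic acid or a longer chain in place of oxolan-2-yl would give a similar step. They also leave open how the opposite configuration at the defined stereocentre would compare.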